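Swapping the aryl group on the ring nitrogen: compound 3 expected

A few compounds are considered here, and "the series" means these few. Any claim that something is new, unique, unknown or untested is made for them only; others in the source may bear on it.

Measured compounds:
Compound 1, `Nc1scc(CN2CCN(c3ccc(Cl)c(C(F)(F)F)c3)CC2)c1C(=O)c1ccc(Cl)cc1`: -12%
Compound 2, `Nc1scc(CN2CCN(c3cccc(F)c3)CC2)c1C(=O)c1ccc(Cl)cc1`: -37%

Both numbers come from a functional assay on CHO cells with adenosine receptor A1 (Homo sapiens) as the target, read by cAMP accumulation and immunoassay, with a stated time of 6 min, tested at 0.1 uM; on this read-out lower numbers stand for a stronger effect and higher numbers for a weaker effect at the one concentration tested. Compound 1 stands highest of the two values known, and the nearest, compound 2, lies a clear distance below it. Among the measured compounds shown here, the single measured step, a number 25 percentage points lower from compound 1 to compound 2 (beyond the scatter), changes only the group on the amine nitrogen in the ring of the shared core, putting a 3-fluorophenyl there. Compound 3, `Nc1scc(CN2CCN(c3cccc(Cl)c3)CC2)c1C(=O)c1ccc(Cl)cc1`, has not yet been measured; it differs from compound 1 by 3-chlorophenyl in place of 4-chloro-3-(trifluoromethyl)phenyl on an amine nitrogen in a ring. For the measured compounds named here, this is the same kind of exchange as the one step that has been measured: the 4-chloro-3-(trifluoromethyl)phenyl leaves and a phenyl carrying a single halogen enters, here chlorine rather than fluorine. That step bears directly on the present one and was modest but beyond the scatter, in the downward direction. A comparable downward move is therefore expected for compound 3, a step of a number 18 percentage points lower from compound 1 to compound 3 (beyond the scatter) in this assay, and compound 3 is estimated at -30%, within -50% to -10%.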

Compound 3, a percentage reported as activity, at one concentration (the size of the read-out at that concentration, not a potency): -20%
For compound 3 the middle estimate is 10 percentage points below the measured one; the measured number falls inside the stated range.
By their numbers in this assay, from the lowest: compound 2; then compounds 3 and 1 (each within the scatter of the next).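

In this assay, exchanging the 4-chloro-3-(trifluoromethyl)phenyl group on the ring nitrogen for 3-chlorophenyl leaves compound 1 and compound 3 indistinguishable (a number 8 percentage points lower from compound 1 to compound 3 (within the scatter)), so the clear step seen earlier with 3-fluorophenyl does not hold for every phenyl carrying a single halogen. The decisive comparison is now between the two single-halogen groups, where chloro in place of fluoro on an aromatic carbon is a one-atom exchange and still gives a modest step beyond the scatter (a number 17 percentage points higher from compound 2 to compound 3 (beyond the scatter)), showing that at this position the identity of the halogen matters more in this read-out than the earlier pair could reveal. The data available offer no measurement that explains this difference between chloro and fluoro.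

The compounds shown leave open how a plain phenyl, a bromo group or a methoxy group on the same ring would compare with compound 2 and compound 3. They also leave open whether the gap between the chloro and fluoro compounds would persist at other concentrations, since each number here comes from a single concentration and is not a potency.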